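Swapping Chloro for Methoxy on a Thiophene-Linked Amidine

This account rests on a few compounds, and the source may have more. Where it says the series, first, only, none or still open, it means among the compounds named here.

Measured compounds so far:
- Compound 1, `N=C(N)c1ccc(-c2ccc(-c3cc(Cl)cc(Cl)c3)s2)cc1`: 1030 nM
- Compound 2, `N=C(N)c1ccc(-c2ccc(-c3ccc(F)cc3)s2)cc1`: 1260 nM
- Compound 3, `N=C(N)c1ccc(-c2ccc(-c3ccc(Cl)cc3)s2)cc1F`: 215 nM

These three compounds share a core and were tested in a functional assay on MDA-MB-468 cells (Homo sapiens) for inhibition, read by sulforhodamine B assay, with a stated time of 48 h; on this read-out lower numbers stand for stronger inhibition of growth and higher numbers for weaker inhibition of growth. Compound 3, which carries a fluorine on the ring bearing the amidine and a chloro on the far ring, gives the lowest number of the three, at 215 nM. Its nearest neighbour is compound 1 at 1030 nM, and the furthest is compound 2 at 1260 nM; both gaps lie beyond the usual scatter, so compound 3 is the most potent of the set as measured.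

The next compound, compound 4, `COc1ccc(-c2ccc(-c3ccc(C(=N)N)c(F)c3)s2)cc1`, differs from compound 3 in one place: methoxy in place of chloro on an aromatic carbon

Among the measured compounds shown here, no pair of measured compounds differs in just this way, so the size of this step cannot be read from the data. A step of modest size, in the direction of weaker growth inhibition in this assay, is expected. Compound 4 is therefore estimated at 400 nM, with a range from 120 nM to 1300 nM, which corresponds to an expected step of a 1.9-fold higher number from compound 3 to compound 4 (0.27 log units; within the scatter).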

Compound 4, concentration for 50% growth inhibition: 1390 nM
Compound 4: the middle estimate sits 3.5-fold (0.54 log units) below what was measured, outside the stated range (above it).
By their numbers in this assay, from the lowest: compound 3; then compounds 1, 2 and 4 (each within the scatter of the next).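

Within this assay the step of a 6.5-fold higher number from compound 3 to compound 4 (0.81 log units; beyond the scatter) gives the first direct reading of this position, para to a large group on the far ring. It shows that the position is not indifferent to its group, since exchanging chloro for methoxy, with the rest of the molecule unchanged, weakens growth inhibition by more than the usual scatter. No measurement here accounts for the size of this loss.

Going by these compounds, it remains open whether the loss comes from gaining the methoxy or from losing the chloro, and groups such as an amine, a hydroxyl or a methyl at this place could help separate the two. On these data alone, it is also open whether the same exchange would give a step of similar size without the fluorine on the ring bearing the amidine.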